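Swapping Methylamino for Ethyl on the Shared Core

The compounds below may be only part of what the source reports. "The series", "measured", "known", "first", "only" and "open" are said of these compounds alone.

Compound 1, `COc1nc(Cl)nc(Nc2ccc(Cl)c(OCC=C(C)C)c2)n1`: in an ADME assay on MT2 cells (Homo sapiens) for cytotoxicity (a lower number here means that less compound is tolerated, a higher number that more compound is tolerated), compound 1 gives 26000 nM.
Compound 2, `COc1nc(Nc2ccc(C#N)c(OCC=C(C)C)c2)nc(OC)n1`: in this assay compound 2 gives > 100000 nM, which is a limit of the assay and not a number.
Compound 3, `CNc1ccnc(Nc2ccc(Cl)c(OCC=C(C)C)c2)n1`: in this assay compound 3 gives 690 nM.

Of the two numbers shown, compound 3 stands lowest, meaning that less of it is tolerated by the cells than of compound 1. The gap to compound 1 is large and lies well beyond the scatter of repeated measurements. The limit at which compound 2 sits is the limit of > 100000 nM in this assay, at which 1 of the 3 values shown sits.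

Compound 4, `CCc1ccnc(Nc2ccc(Cl)c(OCC=C(C)C)c2)n1`, is not yet measured. It differs from compound 3 in one place: ethyl in place of methylamino on an aromatic carbon. Going by the values given here, no pair of measured compounds differs in a single place, so no measured step tells how large such a change is in this assay. The expectation for the step in this assay is therefore modest: a 1.4-fold higher number from compound 3 to compound 4 (0.16 log units; within the scatter), a step that is not expected to go beyond the scatter.

Compound 4 is estimated at 1000 nM in this assay, with a range from 300 nM to 4000 nM.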

Compound 4, half-maximal cytotoxic concentration: 330 nM
The estimate for compound 4 lay 3.0-fold (0.48 log units) above the measured number, and the stated range covers the measured number.
By their numbers in this assay, from the lowest: compound 4; then compound 3; then compound 1. At a limit, above all of these: compound 2.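

In this assay, placing ethyl instead of methylamino on the aromatic carbon next to the ring nitrogen gives a 2.1-fold lower number from compound 3 to compound 4 (0.32 log units; beyond the scatter), so this position responds measurably to the swap, though the step is modest. Going by these compounds alone, this is the first comparison in which only one place differs, and it shows that losing the nitrogen, along with the hydrogen-bond donor and acceptor counted for methylamino, does not raise the number; the cells tolerate less of compound 4 than of compound 3. Nothing measured for these compounds explains why the number moves in this direction.

Going by these compounds, it remains open whether a longer chain such as propyl, or a plain amine on the same carbon, would lower the number further, raise it or leave it within the scatter. A single step also cannot show whether ethyl in place of methylamino would have a similar effect if the chloro group on the other ring were replaced by a nitrile.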